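The source may hold more compounds than are shown below. What is called first, only, known or untested is meant among the compounds shown, and "the series" means these compounds.

Compound 1 `O=C(CC1c2ccccc2N=C(SCCCCCN2CCCC2)N1c1ccc(-c2ccccc2)cc1)NCc1ccc(F)cc1` gives 19800 nM in a functional assay on A549 cells (Homo sapiens) for cytotoxicity, read by MTT assay, with a stated time of 48 h; a higher number here means a weaker inhibitor, a lower number a stronger inhibitor.
Compound 2 `O=C(CC1c2ccccc2N=C(SCCCCCN2CCCC2)N1c1ccc(-c2ccc(F)cc2)cc1)NCc1ccc(F)cc1` gives 12600 nM in this assay.
Compound 3 `O=C(CC1c2ccccc2N=C(SCCCCCN2CCCC2)N1c1ccc(-c2ccc(F)cc2)cc1)NCc1ccccc1` gives 17800 nM in this assay.

Compound 2 has the lowest of the three numbers, but both of its steps, a 1.6-fold lower number from compound 1 to compound 2 (0.20 log units; within the scatter) and a 1.4-fold higher number from compound 2 to compound 3 (0.15 log units; within the scatter), lie within the scatter, so the three compounds are not separated. Compound 4 `O=C(CC1c2ccccc2N=C(SCCCCCN2CCCC2)N1c1ccccc1)NCc1ccc(F)cc1` differs from compound 2 by hydrogen in place of 4-fluorophenyl on an aromatic carbon. Among the compounds with values here, no measured step removes this ring; the only step touching the same ring, a 1.6-fold lower number from compound 1 to compound 2 (0.20 log units; within the scatter), moved nothing beyond the scatter. On that basis no step beyond the scatter is expected in this assay, with a slight lean toward a higher number. The estimate for compound 4 is 22000 nM, between 8000 nM and 60000 nM. The implied step, a 1.7-fold higher number from compound 2 to compound 4 (0.24 log units; within the scatter), is expected to be small.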

Compound 4, half-maximal inhibitory concentration: 89900 nM
The estimate for compound 4 lay 4.1-fold (0.61 log units) below the measured number; the measured number lies above the stated range.
By their numbers in this assay, from the lowest: compounds 2, 3 and 1 (each within the scatter of the next); then compound 4.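

Fluoro on the outer ring moved nothing beyond the scatter, but removing that ring does move the number: this assay shows a 7.1-fold higher number from compound 2 to compound 4 (0.85 log units; beyond the scatter) with hydrogen in place of 4-fluorophenyl and a 4.5-fold higher number from compound 1 to compound 4 (0.66 log units; beyond the scatter) with hydrogen in place of phenyl. At this place, on an aromatic carbon para to a large group, the presence of the ring therefore counts for more than the fluoro it carries. Nothing available explains the size of these steps. The compounds shown leave open whether a smaller group here, such as methyl or methoxy, or a pyridine ring in place of the phenyl, would keep the number as low as the ring-bearing compounds do.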